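The source may hold more compounds than are shown below. What is called first, only, known or untested is meant among the compounds shown, and "the series" means these compounds.

Measured in an ADME assay on MCF7 cells (Homo sapiens) for inhibition; on this read-out lower numbers stand for stronger inhibition and higher numbers for weaker inhibition:
- Compound 1 `COC(=O)c1cc2c(F)c(F)c(Oc3ccccc3Br)c(F)c2s1`: > 25000 nM (a limit)
- Compound 2 `O=C(c1ccccc1)c1cc2c(F)c(F)c(-n3ccnc3)c(F)c2s1`: > 60000 nM (a limit)
- Compound 3 `O=C(c1ccccc1)c1cc2c(F)c(F)c(-n3cnc4ccccc43)c(F)c2s1`: > 25000 nM (a limit)

None of these three compounds has an exact value yet. Compound 3 stands at the limit of > 25000 nM in this assay, at which 2 of the 3 values shown sit, and compound 2 stands at the limit of > 60000 nM in this assay, at which 1 of the 3 values shown sits.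

Compound 4 `O=C(c1ccccc1)c1cc2c(F)c(F)c(Oc3ccccc3Br)c(F)c2s1` has 2-bromophenoxy in place of the 1H-benzimidazol-1-yl of compound 3, on an aromatic carbon: 2-bromophenoxy in place of 1H-benzimidazol-1-yl on an aromatic carbon.

Among the compounds with values here, the only measured step changes a group at this same place: a step that the two limits leave unreadable from compound 2 to compound 3. It therefore gives no size to build on. Compound 1 already carries 2-bromophenoxy on a closely similar core, and it gives only a limit, > 25000 nM. This suggests that the new group need not bring clear inhibition, so no real gain is expected in this assay. The expected change is a step that the limit leaves unreadable from compound 3 to compound 4, and this estimate has no firm direction. For compound 4 the estimated value is 30000 nM, with an expected range of 12000 nM to 60000 nM.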

Compound 4, half-maximal inhibitory concentration: > 25000 nM
Compound 4 ended at the assay's limit; the forecaster's own chance of this, stated with the estimate: 75%; the middle value does not contradict the limit.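

In this assay compound 4 gives > 25000 nM, which is a limit. Within the data shown here, compound 1, compound 2 and compound 3 also give only limits, so no step to compound 4 can be read. The compounds shown leave open how strongly any of them inhibits, and whether any group at this place would give an exact value.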